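This account rests on a few compounds, and the source may have more. Where it says the series, first, only, none or still open, it means among the compounds named here.

In an ADME assay on MDBK cells (Bos taurus) for cytotoxicity (on this read-out higher numbers stand for lower toxicity in this test and lower numbers for higher toxicity in this test), compound 3 `N#Cc1ccccc1Cn1ccc2nc(-c3ccccc3)nc-2c1` gives > 100000 nM as a limit, not a number. Compound 1 `COc1ccccc1Cn1ccc2nc(-c3ccccc3)nc-2c1` gives > 100000 nM as a limit too. Compound 2 `COc1cccc(Cn2ccc3nc(-c4ccccc4)nc-3c2)c1` gives > 100000 nM as a limit too. Among the compounds with values here, the series so far stands at the limit of > 100000 nM in this assay, at which 3 of the 3 values shown sit, with no measured number. Compound 4 `N#Cc1cccc(Cn2ccc3nc(-c4ccccc4)nc-3c2)c1` comes from compound 3 by a single change: 3-cyanophenyl in place of 2-cyanophenyl on a saturated chain carbon bound to an aromatic nitrogen and nothing else. The closest parallel is a step that the two limits leave unreadable from compound 1 to compound 2 as the same shift made with methoxy, while a step that the two limits leave unreadable from compound 1 to compound 3 and a step that the two limits leave unreadable from compound 2 to compound 3 are equally without size. No step beyond the scatter is therefore expected in this assay and no direction can be given. The expected step is a number no higher from compound 3 to compound 4 (the limit leaves the size open) on this estimate. Compound 4 is estimated at 100000 nM with an expected range from 50000 nM to 200000 nM and will probably be reported as a limit again.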

Compound 4, half-maximal cytotoxic concentration: > 100000 nM
Compound 4: no number, only a limit (the forecaster's own chance of this, stated with the estimate: 85%); the middle value sits exactly at the limit.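

No step can be read for compound 4 against compound 1, compound 2 or compound 3 in this assay, as all four compounds sit at one limit: the limit of > 100000 nM in this assay, at which 4 of the 4 values shown sit.

The compounds shown leave open how 3-cyanophenyl and 2-cyanophenyl, or cyano and methoxy, compare in this assay, and what measured number, if any, this series would give.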